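Triazole substituent swap on a bromoquinoline scaffold, HeLa cytotoxicity

The compounds below may be only part of what the source reports. "The series", "measured", "known", "first", "only" and "open" are said of these compounds alone.

Measured compounds:
Compound 1, `COc1nc2ccc(Br)cc2cc1C(c1ccccc1)n1cc(-c2ccc(Br)cc2)nn1`: 6.92%
Compound 2, `CCCCCCCCc1cn(C(c2ccccc2)c2cc3cc(Br)ccc3nc2OC)nn1`: 0.1%

The two measured compounds share a core and differ only in the group attached to one aromatic carbon of the triazole ring. In an ADME assay on HeLa cells (Homo sapiens) for cytotoxicity, read by sulforhodamine B assay, with a stated time of 48 h, tested at 10 uM (a lower number here means less inhibition, a higher number more inhibition at the concentration tested (going by the name of the read-out)), compound 1 gives 6.92%, and compound 2 gives 0.1%. Among the compounds with values here, the single step between them, a number 6.8 percentage points lower from compound 1 to compound 2 (within the scatter), is too small to separate the two compounds, so compound 2 stands alongside compound 1 with no meaningful gap between them.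

Compound 3, `CCOC(=O)c1cn(C(c2ccccc2)c2cc3cc(Br)ccc3nc2OC)nn1`, has not yet been measured in this assay. It differs from compound 2 as follows: ethoxycarbonyl in place of octyl on an aromatic carbon. Within the data shown here, no measured step replaces octyl with ethoxycarbonyl at this position; the only step available, from 4-bromophenyl to octyl, stayed within the scatter. Among the measured compounds shown here, both measured substituents at this carbon gave low inhibition in this assay, and nothing among the measured compounds points to a larger response for compound 3. The step from compound 2 to compound 3 is therefore expected to be small, a number 2.9 percentage points higher from compound 2 to compound 3 (within the scatter), in no particular direction beyond the scatter. Compound 3 is estimated at 3%, within a range of -6% to 13%.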

Compound 3, a percentage reported as inhibition, at one concentration (the size of the read-out at that concentration, not a potency): -3.67%
For compound 3 the middle estimate is 6.7 percentage points above the measured one; low and high end bracket the measured number.
By their numbers in this assay, from the lowest: compounds 3, 2 and 1 (each within the scatter of the next, the first and the last beyond it).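

In this assay, ethoxycarbonyl brings hydrogen-bond acceptors and a carbonyl to this aromatic carbon of the triazole, where octyl has no hydrogen-bond acceptors, yet replacing octyl gives a number 3.8 percentage points lower from compound 2 to compound 3 (within the scatter), so this change in the substituent does not separate the two compounds. Within the data shown here, replacing 4-bromophenyl with ethoxycarbonyl gives a number 10.6 percentage points lower from compound 1 to compound 3 (beyond the scatter), which is the only step at this position to pass the scatter, although it remains modest and compound 2 stands within the scatter of both neighbours, so the three compounds form no clear ladder. Nothing available bears on why the substituents compare in this way.

All three numbers are small and come from one concentration, so the compounds shown leave open whether any substituent at this carbon can produce substantial inhibition in these cells. A carboxylic acid, a primary amine or a hydroxymethyl group here might show whether the read-out can move far from this low range, and a longer chain than octyl might show whether chain length matters at all.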